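Trifluoromethyl for chloro on the pyrimidine of compound 2

The source may hold more compounds than are shown below. What is called first, only, known or untested is meant among the compounds shown, and "the series" means these compounds.

Measured so far, each with its largest response in a functional assay on HEK293 cells with Glucose-dependent insulinotropic receptor (Homo sapiens) as the target, read by cAMP accumulation, with a stated time of 60 min; a higher number here means a larger maximal response, a lower number a smaller maximal response:
compound 1, `CCCS(=O)(=O)N1CC=C(c2ccc3c(c2)CC(C2CCN(C(=O)OC(C)C)CC2)O3)CC1`, gives 61%
compound 2, `CCCS(=O)(=O)N1CC=C(c2ccc3c(c2)CC(C2CCN(c4ncc(Cl)cn4)CC2)O3)CC1`, gives 88%

Compound 2 stands highest of the two numbers; its nearest neighbour is compound 1, and the step of a number 27 percentage points higher from compound 1 to compound 2 (beyond the scatter) lies beyond the scatter. Compound 3, `CCCS(=O)(=O)N1CC=C(c2ccc3c(c2)CC(C2CCN(c4ncc(C(F)(F)F)cn4)CC2)O3)CC1`, differs from compound 2 in one place: trifluoromethyl in place of chloro on an aromatic carbon.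

Among the compounds with values here, no measured step exchanges a substituent on the 5-chloropyrimidin-2-yl group. Within the data shown here, the only step recorded, a number 27 percentage points higher from compound 1 to compound 2 (beyond the scatter), replaces the whole group on the amine nitrogen in a ring and bears on the present change only loosely. For compound 3 the step of a number 3 percentage points lower from compound 2 to compound 3 (within the scatter) is therefore expected to stay within the scatter, in no particular direction. Compound 3 is expected to give 85% in this assay, within a range from 68% to 100%.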

Compound 3, largest response reached (Emax), in percent of the reference or control that the assay uses: 118%
The estimate for compound 3 lay 33 percentage points below the measured number, outside the stated range (above it).
By their numbers in this assay, from the lowest: compound 1; then compound 2; then compound 3.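

Swapping a single substituent on the pyrimidine, on the aromatic carbon para to a large group, proved no minor change: in this assay trifluoromethyl in place of chloro gives a number 30 percentage points higher from compound 2 to compound 3 (beyond the scatter) and takes compound 3 past every other number shown. Until now, only exchange of the whole group on the ring nitrogen had moved the response, and measured against the isopropoxycarbonyl group the 5-(trifluoromethyl)pyrimidin-2-yl group gives a number 57 percentage points higher from compound 1 to compound 3 (beyond the scatter) in the same assay. No measurement shown here accounts for this gain.

With only chloro and trifluoromethyl at this carbon, a single pair cannot show whether the response follows the number of heavy atoms or the fluorines themselves. A nitrile, a methyl or a methoxy group here would begin to separate these readings.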